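Fluoro in place of sulfamoyl: an untested step

A few compounds are considered here, and "the series" means these few. Any claim that something is new, unique, unknown or untested is made for them only; others in the source may bear on it.

Compound 1, `N#CC1CN1C(=O)Nc1ccc(Cl)cc1Cl`: 1100 nM in a functional assay on MCF7 cells (Homo sapiens) for inhibition; a lower number here means a stronger inhibitor, a higher number a weaker inhibitor
Compound 2, `N#CC1CN1C(=O)NCc1ccccc1`: 6000 nM in this assay
Compound 3, `N#CC1CN1C(=O)Nc1ccc(S(N)(=O)=O)cc1`: > 15000 nM in this assay

Among these three, compound 3 is the one with only a limit rather than a number: its value of > 15000 nM marks the ceiling of this assay, and (the limit of > 15000 nM in this assay, at which 1 of the 3 values shown sits). Compound 4, `N#CC1CN1C(=O)Nc1ccc(F)cc1`, differs from compound 3 in a single place: fluoro in place of sulfamoyl on an aromatic carbon. Because compound 1, which carries only a number, gives 1100 nM, the expectation for compound 4 is a step toward stronger inhibition, of the size an at least 5.0-fold lower number from compound 3 to compound 4 (0.69 log units; beyond the scatter), beyond the usual scatter. Compound 4 is therefore estimated at 3000 nM in this assay, with a likely range from 800 nM to 12000 nM.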

Compound 4, half-maximal inhibitory concentration: 2400 nM
Beside the measured number, compound 4's estimate is 1.3-fold (0.10 log units) above it; measured number inside the range.
By their numbers in this assay, from the lowest: compound 1; then compound 4; then compound 2. At a limit, above all of these: compound 3.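

Compound 3 gives > 15000 nM in this assay, and that is a limit, not a number. Fluoro in place of sulfamoyl on this aromatic carbon gives an at least 6.2-fold lower number from compound 3 to compound 4 (0.79 log units; beyond the scatter) and is the first comparison here of two compounds differing in one place, showing that this single position can carry a compound from the limit to a measured value. From the compounds shown here alone, the step has only a lower bound, and its full size stays unknown.

Going by these compounds, how an amine, a methoxy group or a carboxylic acid would behave at this position remains open. So does the result with plain hydrogen there, which would separate the gain from adding fluoro from the gain from removing sulfamoyl.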